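Working notes on a small antiproliferative series

The source may hold more compounds than are shown below. What is called first, only, known or untested is meant among the compounds shown, and "the series" means these compounds.

Measured compounds, values from a functional assay on K562 cells (Homo sapiens) for antiproliferative activity, read by MTT assay, with a stated time of 24 h; a lower number here means a stronger inhibitor, a higher number a weaker inhibitor:
compound 1 `CCN(CC)c1ccc(/C=C/C(=O)c2ccc(OC)c3c2OC(C)(C)C=C3)cc1` — 790 nM
compound 2 `COc1ccc(C(=O)/C=C/c2ccc(C(F)(F)F)cc2)c2c1C=CC(C)(C)O2` — > 10000 nM (a limit)
compound 3 `COc1ccc(C(=O)/C=C/c2ccccc2)c2c1C=CC(C)(C)O2` — > 10000 nM (a limit)

In this assay compound 1 gives 790 nM. Compound 2 reaches only the limit of > 10000 nM. Compound 3 likewise stands at the limit of > 10000 nM, so its position is known only as a limit, (the limit of > 10000 nM in this assay, at which 2 of the 3 values shown sit). The steps of an at least 12-fold higher number from compound 1 to compound 2 (1.10 log units; beyond the scatter) and an at least 12-fold higher number from compound 1 to compound 3 (1.10 log units; beyond the scatter) are both large, while a step that the two limits leave unreadable from compound 2 to compound 3 cannot be read. Compound 4 `COc1ccc(C(=O)/C=C/c2ccc(O)c(Br)c2)c2c1C=CC(C)(C)O2` differs from compound 3 by 3-bromo-4-hydroxyphenyl in place of phenyl on a double-bonded chain carbon bound to a double-bonded chain carbon. Among the measured compounds shown here, no measured step covers a hydroxyl or bromine on that ring; only the diethylamino steps bear on substitution there, and they show that removing the diethylamino raised the number strongly. For compound 4 a modest drop is expected, an at least 1.6-fold lower number from compound 3 to compound 4 (0.22 log units; that floor lies within the scatter), with an estimate of 6000 nM between 1500 nM and 20000 nM.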

Compound 4, half-maximal inhibitory concentration: > 10000 nM
Compound 4: no number, only a limit (the forecaster's own chance of this, stated with the estimate: 45%); middle value at least 1.6-fold (0.22 log units) from the limit.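

Compound 3 and compound 4 both stand only at a limit, so no new step can be read between them: the limit of > 10000 nM in this assay, at which 3 of the 4 values shown sit.

The compounds shown leave open whether 3-bromo-4-hydroxyphenyl in place of phenyl changes the antiproliferative number at all.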